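The source may report more compounds than this note shows. Statements on the series, on what has been measured and on what is new or still open speak of the compounds shown alone.

Compounds measured in a functional assay on HEK293 cells for positive allosteric modulation of metabotropic glutamate receptor 5 (Homo sapiens), read by calcium flux; on this read-out higher numbers stand for larger maximal responses and lower numbers for smaller maximal responses:
- compound 1, `O=C(c1ccc(F)cc1)N1CCc2nc(COc3cccc(F)c3)oc2C1`: 78%
- compound 2, `O=C(c1cccc(F)c1)N1CCc2nc(COc3cccc(F)c3)oc2C1`: 75%

Compound 2 gives the lower of the two numbers in this assay, but its nearest neighbour, compound 1, lies only a number 3 percentage points lower from compound 1 to compound 2 (within the scatter) away, so the two compounds cannot be told apart on these figures. For the measured compounds named here, the only measured step, 3-fluorophenyl in place of 4-fluorophenyl on a carbonyl carbon, moved the read-out by a margin that stays inside the scatter.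

Compound 3, `O=C(c1cccc(F)c1F)N1CCc2nc(COc3cccc(F)c3)oc2C1`, differs from compound 2 by fluoro in place of hydrogen on an aromatic carbon, the same difference read one bond further out as 3-fluorophenyl to 2,3-difluorophenyl. Going by the values given here, no measured pair shows a second fluoro entering this ring, so the step has no direct precedent here. Among the compounds with values here, the one step that is known, from compound 1 to compound 2, stayed within the scatter, and nothing in the data points to a larger movement for a further fluoro on the same ring. The step from compound 2 to compound 3 is therefore expected to be a number 1 percentage points lower from compound 2 to compound 3 (within the scatter), that is, no change beyond the scatter in either direction. For compound 3 the maximal response in this assay is estimated at 74%, with a range from 55% to 92%.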

Compound 3, largest response reached (reported as percent of maximum), in percent of the reference or control that the assay uses: 72%
Estimate against measurement, compound 3: 2 percentage points above; low and high end bracket the measured number.
By their numbers in this assay, from the lowest: compounds 3, 2 and 1 (each within the scatter of the next).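

Compound 3 is the first of these compounds to carry a fluoro on the aromatic carbon ortho to a fluoro group and ortho to a large group, and in this assay this addition gives a number 3 percentage points lower from compound 2 to compound 3 (within the scatter) and so does not separate the two compounds. The comparison with the 4-fluorophenyl amide also stays inside the scatter, with 2,3-difluorophenyl in place of 4-fluorophenyl giving a number 6 percentage points lower from compound 1 to compound 3 (within the scatter) even though this step changes the fluoro pattern more widely than either single step. On these figures, therefore, the 4-fluorophenyl, 3-fluorophenyl and 2,3-difluorophenyl amides cannot be told apart, and no independent data are available to explain this result.

The compounds shown leave open whether this aromatic carbon would give a similar read-out with a chloro, methyl, methoxy or trifluoromethyl group, or with a larger group such as a dimethylamino group or a carboxylic acid. They also leave open how an unsubstituted phenyl ring on the carbonyl would compare with these three fluorinated rings.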